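This account rests on a few compounds, and the source may have more. Where it says the series, first, only, none or still open, it means among the compounds named here.

Measured so far in a physicochemical assay for solubility, with a stated time of 24 h, tested at 30 mg/mL; on this read-out higher numbers stand for higher solubility and lower numbers for lower solubility
compound 1 (`O=C(CCCCCNc1c(Nc2ccccc2)c(=O)c1=O)NO`) gives 2200000 nM
compound 2 (`CN(C)c1ccc(Nc2c(NCCCCCC(=O)NO)c(=O)c2=O)cc1`) gives 1400000 nM
compound 3 (`O=C(CCCCCNc1c(Nc2ccc(C(F)(F)F)cc2)c(=O)c1=O)NO`) gives 4700000 nM

Two measured steps place compound 2 among these values (a 1.6-fold lower number from compound 1 to compound 2 (0.20 log units; within the scatter)) and (a 3.4-fold higher number from compound 2 to compound 3 (0.53 log units; beyond the scatter)). Compound 4 (`C[C@H](CCCCC(=O)NO)Nc1c(Nc2ccc(N(C)C)cc2)c(=O)c1=O`) has methyl in place of hydrogen on a saturated chain carbon bound to a nitrogen on an aromatic ring and a saturated chain carbon. Going by the values given here, no measured step changes that chain. All of them change an aromatic carbon, including the remaining one (a 2.1-fold higher number from compound 1 to compound 3 (0.33 log units; beyond the scatter)), so they bear only indirectly, as a guide to the size of steps among these three compounds. In this assay no step beyond the scatter is therefore expected, in either direction. The step expected is a 1.1-fold higher number from compound 2 to compound 4 (0.03 log units; within the scatter) and it stays within the scatter. The estimate for compound 4 is 1500000 nM and the expected range runs from 700000 nM to 3200000 nM for repeat measurements.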

Compound 4, solubility: 27000000 nM
For compound 4 the middle estimate is 18-fold (1.26 log units) below the measured one, and the stated range ends below it.
By their numbers in this assay, from the lowest: compounds 2 and 1 (each within the scatter of the next); then compound 3; then compound 4.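

In this assay the change of methyl in place of hydrogen on a saturated chain carbon bound to a nitrogen on an aromatic ring and a saturated chain carbon gives a 19-fold higher number from compound 2 to compound 4 (1.29 log units; beyond the scatter) and this exceeds every step among compounds 1, 2 and 3. This chain position therefore moves the read-out further, with one added carbon, than any aromatic carbon change shown. Nothing available accounts for the size of this step.

Open, as far as these compounds go, is whether the opposite configuration of the methyl gives a step of similar size. Also open, from the compounds shown here alone, is whether an ethyl or a hydroxymethyl at this carbon does so, or whether the same methyl does so on the cores of compound 1 and compound 3.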